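The source may hold more compounds than are shown below. What is called first, only, known or untested is meant among the compounds shown, and "the series" means these compounds.

Compound 3 `CC(=O)c1cnc(C(=O)CCCCCCc2ccccc2)o1` gives 2 nM in an assay (Rattus norvegicus) for inhibition of Fatty-acid amide hydrolase 1 (Homo sapiens) (on this read-out lower numbers stand for stronger inhibition and higher numbers for weaker inhibition), the higher of the two numbers shown; its nearest neighbour is compound 2 `NC(=O)c1cccc(-c2cnc(C(=O)CCCCCCc3ccccc3)o2)n1`, which gives 1 nM, a gap within the scatter. Compound 1 `O=C(CCCCCCc1ccccc1)c1ncc(-c2ncccc2C(=O)O)o1` gives only a limit of the assay, > 50 nM. Compound 4 `O=C(CCCCCCc1ccccc1)c1ncc(C(=O)N2CCSCC2)o1` differs from compound 3 by thiomorpholin-4-yl in place of methyl on a carbonyl carbon. Among the compounds with values here, no measured step touches this methyl; the closest comparisons, an at least 25-fold lower number from compound 1 to compound 3 (1.39 log units; beyond the scatter) and an at least 50-fold lower number from compound 1 to compound 2 (1.69 log units; beyond the scatter), swap the whole group on the aromatic carbon. For compound 4 a step of a 1.5-fold higher number from compound 3 to compound 4 (0.18 log units; within the scatter) is expected, nothing beyond the scatter, given that a 2.0-fold higher number from compound 2 to compound 3 (0.30 log units; within the scatter) showed two quite different groups at this carbonyl giving similar numbers. Compound 4 is therefore estimated at 3 nM, between 1 nM and 15 nM.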

Compound 4, inhibition constant: 10 nM
For compound 4 the middle estimate is 3.3-fold (0.52 log units) below the measured one; the measured number falls inside the stated range.
By their numbers in this assay, from the lowest: compounds 2 and 3 (each within the scatter of the next); then compound 4. At a limit, above all of these: compound 1.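

Within the data shown here, replacing the methyl on this carbonyl carbon with thiomorpholin-4-yl gives the first measured change here, and it is not silent: a 5.0-fold higher number from compound 3 to compound 4 (0.70 log units; beyond the scatter), so this position responds to the group it carries while the larger ring still leaves a low number. The same ring compares less well with 6-carbamoylpyridin-2-yl on the aromatic carbon: a 10-fold higher number from compound 2 to compound 4 (1.00 log units; beyond the scatter). Against 3-carboxypyridin-2-yl the reading is an at least 5.0-fold lower number from compound 1 to compound 4 (0.69 log units; beyond the scatter), and it is only a bound, as compound 1 gives a limit: the limit of > 50 nM in this assay, at which 1 of the 4 values shown sits.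

The compounds shown cannot separate the contribution of the ring from that of its sulfur or its amide nitrogen. Morpholin-4-yl or a plain amino group on the same carbonyl carbon would bear on that question.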